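From a Diethylamino Chain to an Anilino Chain

The compounds below may be only part of what the source reports. "The series", "measured", "known", "first", "only" and "open" are said of these compounds alone.

Compound 1, `Cn1c(N)c(-c2nc3ccccc3[nH]2)c2nc(C#N)c(C#N)nc21`, carries a hydrogen on the chain carbon bound to the aromatic nitrogen. In a functional assay on HL-60 cells (Homo sapiens) for antiproliferative activity, read by MTT assay, with a stated time of 48 h (a higher number here means a weaker inhibitor, a lower number a stronger inhibitor), compound 1 gives > 50000 nM, which is a limit of the assay and not a number. Compound 2, `CCN(CC)CCCn1c(N)c(-c2nc3ccccc3[nH]2)c2nc(C#N)c(C#N)nc21`, differs from it by 2-(diethylamino)ethyl in place of hydrogen on a saturated chain carbon bound to an aromatic nitrogen. In this assay compound 2 also gives only a limit, > 730 nM. The step that the two limits leave unreadable from compound 1 to compound 2 therefore cannot be read, as the limit of > 50000 nM in this assay, at which 1 of the 2 values shown sits, and the limit of > 730 nM in this assay, at which 1 of the 2 values shown sits, together show. Going by the values given here, compound 2 thus stands at a limit, and the one further value shown is a limit as well.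

Compound 3, `N#Cc1nc2c(-c3nc4ccccc4[nH]3)c(N)n(CCCNc3ccccc3)c2nc1C#N`, is the next member: anilino in place of diethylamino on a saturated chain carbon, three bonds along the chain from an aromatic nitrogen. Among the compounds with values here, only the step from compound 1 to compound 2 has been measured, and its size is not readable, so no measured step bears on this change. The step that the limit leaves unreadable from compound 2 to compound 3 is therefore expected to be small, with a fair chance that compound 3 again returns only a limit. Compound 3 is estimated at 5000 nM in this assay, within 700 nM to 50000 nM.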

Compound 3, half-maximal inhibitory concentration: 6920 nM
Compound 3: the middle estimate sits 1.4-fold (0.14 log units) below what was measured, within the range that was stated.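

Going by these compounds alone, compound 3 is the only one of the three compounds that gives a number rather than a limit in this assay, which makes this the first change at this position whose size can be stated. The 2-anilinoethyl group in place of hydrogen on a saturated chain carbon bound to an aromatic nitrogen gives an at least 7.2-fold lower number from compound 1 to compound 3 (0.85 log units; beyond the scatter), so a chain ending in anilino on the core of compound 1 lowers the number by more than the usual scatter. The exchange of diethylamino for anilino on the same chain, however, cannot be read in either direction, because compound 2 is held at a limit: the limit of > 730 nM in this assay, at which 1 of the 3 values shown sits.

The compounds shown therefore leave open whether anilino or diethylamino at the end of the chain gives the lower number, and whether the gain from compound 1 rests on the aromatic ring of anilino or on the chain itself. A morpholino or piperidino group at the chain end, a chloro substituent on the anilino ring, or a longer chain could each bear on that question.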